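From methyl to methylamino on a sulfonyl sulfur

This account rests on a few compounds, and the source may have more. Where it says the series, first, only, none or still open, it means among the compounds named here.

Measured so far in an ADME assay on microsomes from liver (Homo sapiens) for metabolic stability (a higher number here means faster removal of the compound, a lower number slower removal), each value a limit:
Compound 1 `CC(C)Oc1cc(Oc2ccc(S(C)(=O)=O)cc2)cc(-c2nccc(=O)[nH]2)c1`: < 9.8 mL/min/kg
Compound 2 `COc1cnc(-c2cc(Oc3ccc(S(C)(=O)=O)cc3)cc(OC(C)C)c2)[nH]c1=O`: < 8 mL/min/kg
Compound 3 `CC(C)Oc1cc(Oc2ccc(S(C)(=O)=O)cc2)cc(-c2ncc(Cl)c(=O)[nH]2)c1`: < 8 mL/min/kg

Compound 1 has no exact clearance to start from, only a limit. It stands at the limit of < 9.8 mL/min/kg in this assay, at which 1 of the 3 values shown sits. Compounds 2 and 3 stand at the limit of < 8 mL/min/kg in this assay, at which 2 of the 3 values shown sit.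

Compound 4 `CNS(=O)(=O)c1ccc(Oc2cc(OC(C)C)cc(-c3nccc(=O)[nH]3)c2)cc1` has not been measured yet. It differs from compound 1 by methylamino in place of methyl on a sulfonyl sulfur, so methylsulfonyl becomes methylsulfamoyl.

The measured steps offer little help. Methoxy in place of hydrogen on an aromatic carbon is a step that the two limits leave unreadable from compound 1 to compound 2. Chloro in place of hydrogen on an aromatic carbon is a step that the two limits leave unreadable from compound 1 to compound 3. Chloro in place of methoxy on an aromatic carbon is a step that the two limits leave unreadable from compound 2 to compound 3. None of these changes touches the sulfonyl sulfur, so none gives a size for the new step.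

The expectation therefore rests on compound 1 , whose < 9.8 mL/min/kg is a limit. The estimated step is a step that the limit leaves unreadable from compound 1 to compound 4, and nothing beyond the scatter is expected. The estimated clearance of compound 4 is 8 mL/min/kg, with an expected range from 5 mL/min/kg to 15 mL/min/kg.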

Compound 4, clearance: < 8 mL/min/kg
Compound 4 was reported as a limit; the forecaster's own chance of this, stated with the estimate: 60%; the middle value lies on the limit itself.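

In this assay, compound 1 and compound 4 are each reported only as a limit, so the step from methylsulfonyl to methylsulfamoyl cannot be read. The compounds shown leave open the actual clearance of either compound, and whether methylamino in place of methyl on a sulfonyl sulfur changes it at all.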